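Acetyl for hydrogen on the salicylate hydroxy of compound 1

The source may report more compounds than this note shows. Statements on the series, on what has been measured and on what is new or still open speak of the compounds shown alone.

Measured so far:
compound 1 `CCOC(=O)c1ccc(/N=N/N(C)C(=O)OCOC(=O)c2ccccc2O)cc1` — 0.567 h
compound 2 `C[C@H](NC(=O)[C@H](N)CC(=O)OCc1ccc(F)cc1)C(=O)O` — 4.33 h

In an ADME assay on a cell-free system (plasma, Homo sapiens) for metabolic stability (a lower number here means that the compound disappears faster, a higher number that the compound lasts longer), compound 1 gives 0.567 h, the lowest of the two numbers; its nearest neighbour, compound 2, gives 4.33 h, a gap beyond the scatter. Compound 3 `CCOC(=O)c1ccc(/N=N/N(C)C(=O)OCOC(=O)c2ccccc2OC(C)=O)cc1` is not yet measured. It differs from compound 1 by acetyl in place of hydrogen on an oxygen on an aromatic ring, in words acetyl in place of hydrogen on an oxygen on an aromatic ring. Among the measured compounds shown here, no step between measured compounds covers this change, so the expectation rests on compound 1 alone. The step from compound 1 to compound 3 is expected to be a 1.3-fold lower number from compound 1 to compound 3 (0.10 log units; within the scatter), a modest shortening that may not clear the scatter. Compound 3 is estimated at 0.45 h in this assay, with a range from 0.2 h to 1 h.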

Compound 3, half-life: 0.0167 h
For compound 3 the middle estimate is 27-fold (1.43 log units) above the measured one; the measured number lies below the stated range.
By their numbers in this assay, from the lowest: compound 3; then compound 1; then compound 2.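

Hydroxy to acetoxy on an oxygen on an aromatic ring is a large change in this assay, giving a 34-fold lower number from compound 1 to compound 3 (1.53 log units; beyond the scatter). The half-life at this position therefore responds strongly to this single change, which compound 1 alone could not show. No measurement bears on how compound 3 is lost, and the step remains without an assigned cause. As far as these compounds go, whether a methyl ether or a longer acyl chain such as butanoyl on this oxygen would lie nearer compound 1 or compound 3 remains open. So does whether any such group would keep the half-life of compound 1.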